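The compounds below may be only part of what the source reports. "The series", "measured", "known", "first", "only" and "open" are said of these compounds alone.

Measured so far:
- compound 1, `CCN1CCCC1CNC(=O)c1cc(NS(=O)(=O)N(C)C)c(Cl)cc1OC`: 8.3 mg/kg
- compound 2, `CCN1CCCC1CNC(=O)c1cc(NS(C)(=O)=O)ccc1OC`: > 50 mg/kg
- compound 3, `CCN1CCCC1CNC(=O)c1cc(NS(C)(=O)=O)c(C)cc1OC`: 35.6 mg/kg

In a functional assay on the whole organism for inhibition, with Mus musculus as the target (on this read-out lower numbers stand for an effect already at smaller amounts and higher numbers for an effect only at larger amounts of compound), compound 3 gives 35.6 mg/kg, the highest of the two numbers. Its nearest neighbour is compound 1, which gives 8.3 mg/kg, a gap beyond the scatter. Compound 2 reaches only a limit of the assay, > 50 mg/kg, so the limit of > 50 mg/kg in this assay, at which 1 of the 3 values shown sits, is all that is known of it.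

The unmeasured compound 4, `CCN1CCCC1CNC(=O)c1cc(NS(C)(=O)=O)c(Cl)cc1OC`, differs from compound 3 in one place: chloro in place of methyl on an aromatic carbon.

Within the data shown here, only one measured step touches the same position: an at least 1.4-fold lower number from compound 2 to compound 3 (0.14 log units; that floor lies within the scatter), and its floor lies within the scatter. Among the measured compounds shown here, no measured pair shows chloro in place of methyl directly. Compound 1, which carries chloro at that position but a different sulfonamide, gives 8.3 mg/kg, a lower number than compound 3; the pair is not a single-point step, so it can only hint.

Compound 4 is expected at 15 mg/kg, within 6 mg/kg to 40 mg/kg. The step expected is a 2.4-fold lower number from compound 3 to compound 4 (0.38 log units; beyond the scatter), a lower number, modest and not far beyond the scatter.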

Compound 4, dose for half-maximal effect: 9.1 mg/kg
For compound 4 the middle estimate is 1.6-fold (0.22 log units) above the measured one; the range from low to high includes it.
By their numbers in this assay, from the lowest: compounds 1 and 4 (each within the scatter of the next); then compound 3. At a limit, above all of these: compound 2.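

Methyl and chloro are not interchangeable at this position: chloro in place of methyl gives a 3.9-fold lower number from compound 3 to compound 4 (0.59 log units; beyond the scatter) in this assay, the first direct measure of this change. With hydrogen at the same position the comparison gives only a floor, an at least 5.4-fold lower number from compound 2 to compound 4 (0.73 log units; beyond the scatter), as compound 2 stands at a limit: the limit of > 50 mg/kg in this assay, at which 1 of the 4 values shown sits. With chloro in place, the group on the sulfonyl sulfur makes no readable difference, since methyl in place of dimethylamino gives a 1.1-fold higher number from compound 1 to compound 4 (0.04 log units; within the scatter).

The compounds shown leave open how bromo, a nitrile or an amine would fare at this position on the aromatic ring. They also leave open whether a longer chain on the sulfonyl sulfur, such as propyl, would match methyl and dimethylamino.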